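The compounds below may be only part of what the source reports. "The series", "measured", "known", "first", "only" and "open" are said of these compounds alone.

Of the compounds shown here, two have so far been measured in a functional assay (Cortical neurone cells, Rattus norvegicus, strain Sprague-Dawley), read by spectrophotometry and LDH release, with stated times of 1 h and 24 h, tested at 1 uM; a lower number here means a weaker effect, a higher number a stronger effect of the compound at the concentration tested. Compound 1 `COc1ccc(/C=C/C(=O)OC[C@H]2O[C@@H](O[C@@H]3OC=C[C@@]4(O)[C@H](O)C[C@](C)(O)[C@@H]34)[C@H](O)[C@@H](O)[C@@H]2O)cc1` gives 60.9%, and compound 2 `COc1ccc(/C=C\C(=O)O[C@@]2(C)C[C@@H](O)[C@]3(O)C=CO[C@@H](O[C@@H]4O[C@H](CO)[C@@H](O)[C@H](O)[C@H]4O)[C@@H]32)cc1` gives 48.2%. Compound 1 stands highest of the two numbers, with compound 2 sitting lower by a gap beyond the usual scatter of the method. The next compound, compound 3 `COc1ccc(/C=C\C(=O)OC[C@H]2O[C@@H](O[C@@H]3OC=C[C@@]4(O)[C@H](O)C[C@](C)(O)[C@@H]34)[C@H](O)[C@@H](O)[C@@H]2O)cc1`, has not yet been measured in this assay. Its difference from compound 1 is confined to one place: the two compounds have the same atoms and bonds and differ only in configuration as drawn: 1 of 11 stereo elements differ; a double bond is drawn E in compound 1 and Z in compound 3. For the measured compounds named here, no step between two measured compounds of this kind is available, so there is nothing to scale the change against. The atoms and bonds are unchanged. Only a modest step is expected, if any beyond the scatter, and a step of a number 4.9 percentage points lower from compound 1 to compound 3 (within the scatter) is the expectation. Compound 3 is accordingly expected to give about 56% in this assay, within a range from 42% to 70%.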

Compound 3, a percentage reported as activity, at one concentration (the size of the read-out at that concentration, not a potency): 47.6%
Compound 3: middle estimate off by 8.4 percentage points, on the high side, within the range that was stated.
By their numbers in this assay, from the lowest: compounds 3 and 2 (each within the scatter of the next); then compound 1.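

For the compounds shown here, until now no step isolated a single change, so nothing showed how much any one feature of these molecules matters. In this assay, switching a single double bond from E to Z gives a number 13.3 percentage points lower from compound 1 to compound 3 (beyond the scatter), so geometry alone, with no atom added or removed, can shift the read-out by a modest step beyond the usual scatter. The step can be assigned to that double bond because nothing else separates the pair: the fact that compounds 1 and 3 differ only in the configuration as drawn

The compounds shown leave open whether the same switch would act the same way in compound 2, whose double bond is drawn Z and which has no E partner here. They also leave open how the read-out would respond to a new group on the shared core, such as an amine or a carboxylic acid.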